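This account rests on a few compounds, and the source may have more. Where it says the series, first, only, none or still open, it means among the compounds named here.

Working notes on the series in a functional assay on MCF7 cells (Homo sapiens) for inhibition, read by MTT assay, with a stated time of 72 h; on this read-out lower numbers stand for stronger inhibition of growth and higher numbers for weaker inhibition of growth. Three members have been run. Compound 1 `O=S(=O)(NCCCCNCc1ccc(Br)cc1)c1cc(C(F)(F)F)cc(C(F)(F)F)c1` gives 1500 nM, compound 2 `O=S(=O)(NCCCNCC1COc2ccccc2O1)c1cc(C(F)(F)F)cc(C(F)(F)F)c1` gives 2500 nM and compound 3 `O=S(=O)(NCCCNCc1cccc2ccccc12)c1cc(C(F)(F)F)cc(C(F)(F)F)c1` gives 1400 nM. Compound 3 holds the lowest of the three numbers, yet its gaps to compound 1 and to compound 2 both sit within the scatter, so the three cannot be ranked against one another. Within the data shown here, the one single-point step measured so far, a 1.8-fold lower number from compound 2 to compound 3 (0.25 log units; within the scatter), is also within the scatter; it is the only step that touches the group on the saturated chain carbon bound to the amine nitrogen. Compound 4 `COc1ccc(CNCCCNS(=O)(=O)c2cc(C(F)(F)F)cc(C(F)(F)F)c2)cc1` is the next candidate; it differs from compound 3 by 4-methoxyphenyl in place of naphthalen-1-yl on a saturated chain carbon bound to an amine nitrogen. Since the earlier swap at this same position moved the number by less than the scatter, and since compound 1, with a different single-ring group on its chain carbon, gives 1500 nM, no step beyond the scatter is expected in this assay for compound 4 either. The change from compound 3 to compound 4 is estimated at a 1.4-fold higher number from compound 3 to compound 4 (0.15 log units; within the scatter). Compound 4 is therefore expected to give about 2000 nM, with a range from 900 nM to 4500 nM.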

Compound 4, concentration for 50% growth inhibition: 2500 nM
Compound 4: the middle estimate sits 1.3-fold (0.10 log units) below what was measured; measured number inside the range.
By their numbers in this assay, from the lowest: compounds 3, 1, 2 and 4 (each within the scatter of the next).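

In this assay, the position on a saturated chain carbon bound to an amine nitrogen now carries three groups on otherwise matched structures, and 4-methoxyphenyl stays within the scatter of both naphthalen-1-yl (a 1.8-fold higher number from compound 3 to compound 4 (0.25 log units; within the scatter)) and 2,3-dihydro-1,4-benzodioxin-2-yl (no change at the digits printed from compound 2 to compound 4 (within the scatter)), so neither the loss of one of the two aromatic rings of naphthalen-1-yl nor the entry of the methoxy oxygen gives a separable step here. The wider change of (4-methoxybenzyl)amino in place of ((4-bromobenzyl)amino)methyl also stays within the scatter (a 1.7-fold higher number from compound 1 to compound 4 (0.22 log units; within the scatter)), so compound 1 cannot be separated from compound 4 either. No measurement at hand accounts for these numbers.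

On these data alone, what remains open is whether any group at this position gives a step beyond the scatter, for instance a cyclohexyl or pyridin-4-yl group in place of 4-methoxyphenyl, or a ring bearing a carboxylic acid or a dimethylamino group. The chain also stays unresolved, since 4-methoxybenzyl on the longer chain of compound 1 or 4-bromobenzyl on the chain of compound 4 would separate the chain from the ring substituent.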